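The source may report more compounds than this note shows. Statements on the series, on what has been measured and on what is new or still open speak of the compounds shown alone.

Measured in a functional assay on DLD-1 cells (Homo sapiens) for cytotoxicity, with a stated time of 48 h; on this read-out lower numbers stand for stronger inhibition and higher numbers for weaker inhibition:

Compound 1 `Cc1cccc2c(=O)cc(/C=C/[S+](C)[O-])oc12`: 6800 nM
Compound 3 `Cc1cccc2oc(/C=C/[S+](C)[O-])cc(=O)c12`: 5500 nM
Compound 2 `COc1cccc2oc(/C=C/[S+](C)[O-])cc(=O)c12`: only a limit of the assay, > 10000 nM

Compound 1 and compound 3 are built from the same atoms joined differently; the difference between the two cores is not broken down here. Their two numbers in this assay sit within the scatter of each other.

From compound 3 to compound 2 the change is methoxy in place of methyl on an aromatic carbon, and it gives an at least 1.8-fold higher number from compound 3 to compound 2 (0.25 log units; that floor lies within the scatter), with compound 2 sitting at the limit of > 10000 nM in this assay, at which 1 of the 3 values shown sits.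

Compound 4 `COc1cccc2c(=O)cc(/C=C/[S+](C)[O-])oc12`, not yet measured, carries the same change relative to compound 1, (methoxy in place of methyl on an aromatic carbon). From compound 1 to compound 4 the expected step in this assay is a 1.9-fold higher number from compound 1 to compound 4 (0.28 log units; within the scatter), resting on the measured step of an at least 1.8-fold higher number from compound 3 to compound 2 (0.25 log units; that floor lies within the scatter). Compound 4 is therefore estimated at 13000 nM, expected between 6000 nM and 30000 nM, likely reported only as a limit.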

Compound 4, half-maximal inhibitory concentration: 9000 nM
The estimate for compound 4 lay 1.4-fold (0.16 log units) above the measured number; low and high end bracket the measured number.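

In this assay, methoxy in place of methyl on an aromatic carbon gives a 1.3-fold higher number from compound 1 to compound 4 (0.12 log units; within the scatter), so on the core of compound 1 this change shifts the number by no more than the usual scatter. Whether the change carries from one core to the other with the same size is not settled: the same change on two cores in this assay, an at least 1.8-fold higher number (0.25 log units; that floor lies within the scatter) from compound 3 to compound 2 and a 1.3-fold higher number (0.12 log units; within the scatter) from compound 1 to compound 4; the limit leaves it open whether they differ Compound 2 gives only a limit of the assay, > 10000 nM.

The compounds shown carry only methyl and methoxy at this place, so the effect of an amine, a carboxylic acid or a longer chain there remains open. Also open, from the compounds shown here alone, is whether any group at this place would give a step beyond the scatter in this assay.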